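Compound 4: a side-chain amine change on the shared core

A few compounds are considered here, and "the series" means these few. Any claim that something is new, unique, unknown or untested is made for them only; others in the source may bear on it.

Values in an ADME assay on L6 cells (Rattus norvegicus) for cytotoxicity, read by resazurin assay, with a stated time of 72 h; a higher number here means a weaker inhibitor, a lower number a stronger inhibitor:
- compound 1 `CN(C)C12CC(c3ccccc3)C(CN(C(=O)CN3CCCCC3)C1)C(c1ccccc1)C2`: 12100 nM
- compound 2 `CN1CCN(CC(=O)N2CC3C(c4ccccc4)CC(N(C)C)(CC3c3ccccc3)C2)CC1`: 9250 nM
- compound 3 `CN(C)C12CC(c3ccccc3)C(CN(C(=O)CCN3CCCC3)C1)C(c1ccccc1)C2`: 11700 nM

Compound 2, at 9250 nM, lies within the scatter of both other compounds, so no order can be read among the three. Compound 4 `CN(C)C12CC(c3ccccc3)C(CN(C(=O)CCN3CCCCC3)C1)C(c1ccccc1)C2` differs from compound 2 by one change: (piperidin-1-yl)methyl in place of 4-methylpiperazin-1-yl on a saturated chain carbon bound to a carbonyl carbon.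

The closest measured change is a 1.3-fold higher number from compound 2 to compound 3 (0.10 log units; within the scatter). Also relevant are a 1.3-fold lower number from compound 1 to compound 2 (0.12 log units; within the scatter) and a 1.0-fold lower number from compound 1 to compound 3 (0.01 log units; within the scatter). All three lie within the scatter, so no shift beyond it is expected in this assay. The expected step is a 1.2-fold higher number from compound 2 to compound 4 (0.08 log units; within the scatter). For compound 4 the estimated value is 11000 nM, with an expected range of 7000 nM to 17000 nM.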

Compound 4, half-maximal inhibitory concentration: 12400 nM
Compound 4: the middle estimate sits 1.1-fold (0.05 log units) below what was measured; the measured number falls inside the stated range.
By their numbers in this assay, from the lowest: compounds 2, 3, 1 and 4 (each within the scatter of the next).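

In this assay the new side chain gives three steps: a 1.3-fold higher number from compound 2 to compound 4 (0.13 log units; within the scatter) and a 1.1-fold higher number from compound 3 to compound 4 (0.03 log units; within the scatter) and a 1.0-fold higher number from compound 1 to compound 4 (0.01 log units; within the scatter). With 2-(piperidin-1-yl)ethyl on the carbonyl carbon, all four compounds now lie within the scatter of one another, so neither the ring amine nor the chain change separates them at this place.

On these data alone, whether a morpholine ring or a carboxylic acid in place of the side-chain amine would move the number beyond the scatter stays open. No evidence on the origin of these values is available.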